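A few compounds are considered here, and "the series" means these few. Any claim that something is new, unique, unknown or untested is made for them only; others in the source may bear on it.

In an ADME assay on HEK293 cells (Homo sapiens) for cytotoxicity, read by MTT assay, with a stated time of 36 h (on this read-out lower numbers stand for stronger inhibition and higher numbers for weaker inhibition), the measured compounds stand as follows:

Compound 1 `O=C(c1ccc2c(c1)OCCO2)C1CCN(Cc2coc(-c3ccccc3)n2)CC1` gives > 150 ug/mL, a limit of the assay.
Compound 2 `O=C(c1ccc2c(c1)OCCO2)C1CCN(Cc2coc(-c3ccc(C(F)(F)F)cc3)n2)CC1` gives > 150 ug/mL, a limit of the assay.
Compound 3 `Cc1ccc(-c2nc(CN3CCC(C(=O)c4ccc5c(c4)OCCO5)CC3)co2)cc1` gives > 150 ug/mL, a limit of the assay.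

Compound 3 therefore stands where every measured compound stands, at the limit of > 150 ug/mL in this assay, at which 3 of the 3 values shown sit. Because all three values sit at that limit, the steps among them cannot be sized: a step that the two limits leave unreadable from compound 1 to compound 2, a step that the two limits leave unreadable from compound 1 to compound 3 and a step that the two limits leave unreadable from compound 2 to compound 3 are each unreadable.

Compound 4 `O=C(c1ccc2c(c1)OCCO2)C1CCN(Cc2coc(-c3ccoc3)n2)CC1` differs from compound 3 in one place: furan-3-yl in place of 4-methylphenyl on an aromatic carbon. Among the measured compounds shown here, none of the measured steps gives a readable size that bears on this change, so the only guidance is that the measured compounds all sit at the limit. Compound 4 is expected to behave the same way, with no step beyond the scatter, that is a number no higher from compound 3 to compound 4 (the limit leaves the size open). The estimate for compound 4 in this assay is 150 ug/mL, in the range 100 ug/mL to 300 ug/mL, with the result most likely reported again only as a limit.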

Compound 4, half-maximal inhibitory concentration: > 150 ug/mL
Compound 4 gave a limit, no number (the forecaster's own chance of this, stated with the estimate: 85%); the middle value lies on the limit itself.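

Among the compounds shown here, compound 4 gives > 150 ug/mL, a limit and not a number, so no step between compound 4 and compound 1, compound 2 or compound 3 can be read. The compounds shown leave open what number any of them would give, and so whether these aromatic groups differ at all: the limit of > 150 ug/mL in this assay, at which 4 of the 4 values shown sit.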